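Cyclohexylmethyl in place of propyl on the core nitrogen

The compounds below may be only part of what the source reports. "The series", "measured", "known", "first", "only" and "open" are said of these compounds alone.

Compound 1: `CC(C)c1onc(-c2c(Cl)cccc2Cl)c1COc1ccc(-c2nc3ccc(C(=O)O)cc3n2C2CC2)cc1` — 117 nM
Compound 2: `CCCn1c(-c2ccc(OCc3c(-c4c(Cl)cccc4Cl)noc3C(C)C)cc2)nc2ccc(C(=O)O)cc21` — 96.4 nM

Of the compounds shown here, two have been measured in an assay on isolated protein for agonist activity at Bile acid receptor (Homo sapiens), read by TR-FRET; a higher number here means that more compound is needed for the effect, a lower number that less compound is needed. Compound 1 `CC(C)c1onc(-c2c(Cl)cccc2Cl)c1COc1ccc(-c2nc3ccc(C(=O)O)cc3n2C2CC2)cc1` gives 117 nM, and compound 2 `CCCn1c(-c2ccc(OCc3c(-c4c(Cl)cccc4Cl)noc3C(C)C)cc2)nc2ccc(C(=O)O)cc21` gives 96.4 nM. Among the compounds with values here, the only measured step, a 1.2-fold lower number from compound 1 to compound 2 (0.08 log units; within the scatter), concerns the group on the aromatic nitrogen; the two values lie within the scatter of each other, so compound 2 stands at the same level as compound 1 rather than apart from it.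

Compound 3 `CC(C)c1onc(-c2c(Cl)cccc2Cl)c1COc1ccc(-c2nc3ccc(C(=O)O)cc3n2CC2CCCCC2)cc1` carries the change (cyclohexyl in place of ethyl on a saturated chain carbon bound to an aromatic nitrogen). The step from compound 1 to compound 2 is the only one that bears on this position, and it shows that swapping cyclopropyl for propyl there leaves this assay unchanged. Within the data shown here, the move from propyl to cyclohexylmethyl is a larger alteration of the same group, for which no measured pair exists. The expectation is therefore a step no larger than the scatter, in either direction, with wider uncertainty than for the measured pair. Compound 3 is expected to show a 1.1-fold higher number from compound 2 to compound 3 (0.06 log units; within the scatter), giving an estimate of 110 nM with a range from 35 nM to 350 nM.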

Compound 3, half-maximal effective concentration: 19.9 nM
For compound 3 the middle estimate is 5.5-fold (0.74 log units) above the measured one, and the stated range ends above it.
By their numbers in this assay, from the lowest: compound 3; then compounds 2 and 1 (each within the scatter of the next).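

In this assay the group on the aromatic nitrogen turns out to matter: cyclohexyl in place of ethyl on a saturated chain carbon bound to an aromatic nitrogen gives a 4.8-fold lower number from compound 2 to compound 3 (0.69 log units; beyond the scatter) and cyclohexylmethyl in place of cyclopropyl gives a 5.9-fold lower number from compound 1 to compound 3 (0.77 log units; beyond the scatter), both steps beyond the scatter. The earlier exchange of cyclopropyl for propyl, a 1.2-fold lower number from compound 1 to compound 2 (0.08 log units; within the scatter), had suggested a position indifferent to its substituent, but that holds only for those two groups, and cyclohexylmethyl separates compound 3 from both of them. Nothing measured here accounts for this step, and the compounds offer no explanation of it.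

The three compounds leave open whether the step belongs to the six-membered ring or simply to the larger number of carbons, which an open chain such as hexyl on the same nitrogen would help to separate. They also leave open how much the carbon linking the ring to the nitrogen contributes, and whether cyclohexyl set directly on the nitrogen, or a phenyl ring in benzyl, would behave as cyclohexylmethyl does.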